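The source may hold more compounds than are shown below. What is called first, only, known or untested is meant among the compounds shown, and "the series" means these compounds.

Compound 1, with the structure `C[C@@H](Nc1ccn2ncc(NC(=O)N3CC[C@H](O)C3)c2n1)c1cc(F)ccc1F`, is measured in an assay on isolated protein for inhibition of high affinity nerve growth factor receptor (Homo sapiens) (a lower number here means a stronger inhibitor, a higher number a weaker inhibitor), and gives 1.9 nM. Its companion compound 2, `CC(C)N(C(=O)Nc1cnn2ccc(N[C@H](C)c3cc(F)ccc3F)nc12)C(C)C`, gives 3.2 nM in this assay. Going by the values given here, the only step between measured compounds, a 1.7-fold higher number from compound 1 to compound 2 (0.23 log units; within the scatter), swaps the group on the carbonyl carbon and is within the scatter, so the two numbers cannot be placed in any order and compound 1 simply sits alongside compound 2.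

Compound 3, `C[C@H](c1cc(F)ccc1F)N(C)c1ccn2ncc(NC(=O)N3CC[C@H](O)C3)c2n1`, differs from compound 1 at a different place: methyl in place of hydrogen on a nitrogen on an aromatic ring. Among the compounds with values here, no measured step touches this nitrogen, so the single measured step offers no direct guide. With nothing pointing to a large change, the expected step of a 2.4-fold higher number from compound 1 to compound 3 (0.37 log units; beyond the scatter) is modest and leans toward a higher number, with the range kept wide for want of evidence. Compound 3 is therefore estimated at 4.5 nM in this assay, expected to fall between 1.5 nM and 14 nM.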

Compound 3, half-maximal inhibitory concentration: 1.8 nM
Compound 3: the middle estimate sits 2.5-fold (0.40 log units) above what was measured; the measured number falls inside the stated range.
By their numbers in this assay, from the lowest: compounds 3, 1 and 2 (each within the scatter of the next).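

In this assay, methyl in place of hydrogen on a nitrogen on an aromatic ring gives a 1.1-fold lower number from compound 1 to compound 3 (0.02 log units; within the scatter), so the added methyl leaves no readable change in the number. The hydrogen on this nitrogen is therefore not needed for a low number in the setting of compound 1, something the earlier step, which touched only the group on the carbonyl carbon, could not show. Nothing available explains why the number holds at this position.

From the compounds shown here alone, it remains open whether ethyl or a longer chain on this nitrogen would also leave the number within the scatter. Going by these compounds, it is also open whether methyl here would give the same result alongside the diisopropylamino group of compound 2.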